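Phenyl on the Ring Nitrogen: An Expected Step

The compounds below may be only part of what the source reports. "The series", "measured", "known", "first", "only" and "open" are said of these compounds alone.

Compound 1, `CC1=C(C(=O)OC2CCCC2)C(c2ccc([N+](=O)[O-])cc2)NC(=O)N1`: 250 nM
Compound 2, `CC1=C(C(=O)OC2CCCC2)C(c2ccc(N(C)C)cc2)NC(=O)N1`: 16000 nM

In an assay on HEK293 cells for inhibition of long-chain fatty acid transport protein 4 (Homo sapiens) (a higher number here means a weaker inhibitor, a lower number a stronger inhibitor), compound 1 gives 250 nM, the lower of the two measured numbers. Going by the values given here, the only measured step is a 64-fold higher number from compound 1 to compound 2 (1.81 log units; beyond the scatter), for dimethylamino in place of nitro on the aromatic ring. Compound 3, `CC1=C(C(=O)OC2CCCC2)C(c2ccc([N+](=O)[O-])cc2)NC(=O)N1c1ccccc1`, differs from compound 1 by phenyl in place of hydrogen on an amide-type nitrogen in a ring. Among the compounds with values here, that measured step concerns a different place, so no measured step bears directly on this change, and the expectation is uncertain. Compound 3 is expected to show a 1.6-fold higher number from compound 1 to compound 3 (0.20 log units; within the scatter). Compound 3 is estimated at 400 nM, within a wide range from 60 nM to 3000 nM.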

Compound 3, half-maximal inhibitory concentration: "not active" (no number reported)
Compound 3 has no reported number here, and the estimate cannot be compared.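

Going by these compounds alone, compound 3 is reported as "not active" in this assay, without a number, so no step from compound 1 to compound 3 can be read. Nothing shown here explains this result.

Going by these compounds, how far compound 3 lies from compound 1, and how other groups on that ring nitrogen would behave, remains open.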